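Chloro in Place of Fluoro: What Compound 4 May Show

The source may report more compounds than this note shows. Statements on the series, on what has been measured and on what is new or still open speak of the compounds shown alone.

Compound 1 `COc1ccccc1NC(=O)NC1CC(C)(C)Oc2ccc(F)cc21` was tested in a functional assay (aorta) with Rattus norvegicus as the target; a higher number here means that more compound is needed for the effect, a lower number that less compound is needed. In this assay compound 1 gives only a limit, > 10000 nM. Compound 2 `COc1ccccc1NC(=O)NC1CC(C)(C)Oc2ccc(Cl)cc21` carries chloro in place of fluoro on an aromatic carbon relative to compound 1. In this assay compound 2 likewise reaches only a limit, > 10000 nM. The step that the two limits leave unreadable from compound 1 to compound 2 therefore cannot be sized, as the limit of > 10000 nM in this assay, at which 2 of the 3 values shown sit, shows. Compound 3 `CC1(C)CC(NC(=O)Nc2ccc(Cl)cc2)c2cc(F)ccc2O1` differs from compound 1 by 4-chlorophenyl in place of 2-methoxyphenyl on an amide-type nitrogen. In this assay compound 3 gives a limit too, > 30000 nM. The step that the two limits leave unreadable from compound 1 to compound 3 remains unreadable, with the limit of > 30000 nM in this assay, at which 1 of the 3 values shown sits, marking where compound 3 sits. Compound 4 `CC1(C)CC(NC(=O)Nc2ccc(Cl)cc2)c2cc(Cl)ccc2O1` is not yet measured; it differs from compound 3 by chloro in place of fluoro on an aromatic carbon, the same change as that from compound 1 to compound 2, at a place described in the same words. The step that the two limits leave unreadable from compound 1 to compound 2 offers no size to lean on. Compound 4 is thus expected to stay at a limit, with an estimate of 30000 nM in this assay. The expected step is a number no higher from compound 3 to compound 4 (the limit leaves the size open).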

Compound 4, half-maximal effective concentration: > 300000 nM
Compound 4: no number, only a limit (the forecaster's own chance of this, stated with the estimate: 85%); at least 10-fold (1.00 log units) between middle value and limit.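

In this assay compound 4 gives only a limit, > 300000 nM, so no new step can be read from compound 3 or compound 2 to compound 4. The compounds shown leave open how much compound any of these needs for the effect.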